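A few compounds are considered here, and "the series" means these few. Any claim that something is new, unique, unknown or untested is made for them only; others in the source may bear on it.

Measured compounds:
compound 1, `CCc1csc(CN[C@@H]2C[C@H]3C[C@@H]([C@H]2C)C3(C)C)c1`: 25000 nM
compound 2, `C[C@H]1[C@H](NCc2ccc(Br)s2)C[C@H]2C[C@@H]1C2(C)C`: 43000 nM
compound 3, `C[C@H]1[C@H](NCc2sccc2C2CCCC2)C[C@H]2C[C@@H]1C2(C)C`: 12500 nM

In an ADME assay on MDCK cells (Canis lupus familiaris) for cytotoxicity, read by microscopy, with a stated time of 48 h (on this read-out higher numbers stand for lower toxicity in this test and lower numbers for higher toxicity in this test), compound 1 gives 25000 nM. Among the three numbers to hand compound 1 stands second highest. The nearest is compound 2 with 43000 nM, which lies within the usual scatter of this measurement, and the furthest is compound 3 with 12500 nM, which also lies within the scatter. The three numbers therefore do not separate from one another, and no step between two compounds that differ in a single place is available in this series, so nothing about the size of any single change has yet been shown.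

Compound 4 `C[C@H]1[C@H](NCc2cc(-c3ccccc3)cs2)C[C@H]2C[C@@H]1C2(C)C` is not yet measured in this assay. Relative to compound 1 the change is phenyl in place of ethyl on an aromatic carbon. Without a measured step of this kind, the expectation for compound 4 is a modest step from compound 1 toward a lower number, of a size that may not clear the scatter; the step expected is a 1.7-fold lower number from compound 1 to compound 4 (0.22 log units; within the scatter). The estimate for compound 4 in this assay is 15000 nM, with a range from 6000 nM to 40000 nM.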

Compound 4, minimum cytotoxic concentration: 5000 nM
Beside the measured number, compound 4's estimate is 3.0-fold (0.48 log units) above it, outside the stated range (below it).
By their numbers in this assay, from the lowest: compound 4; then compounds 3, 1 and 2 (each within the scatter of the next, the first and the last beyond it).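

In this assay, among the compounds shown here, phenyl in place of ethyl on an aromatic carbon gives a 5.0-fold lower number from compound 1 to compound 4 (0.70 log units; beyond the scatter), the first step between two compounds that differ in one place, and it clears the scatter. This position, two ring bonds from the ring sulfur and two ring bonds from the ring atom that bears a large group, therefore does register on this read-out: with the rest of compound 1 unchanged, the exchange of ethyl for phenyl goes with higher toxicity in this test. No measurement at hand accounts for the step.

This single pair cannot separate the effect of the aromatic ring from that of the larger number of heavy atoms; a longer chain such as butyl, or a saturated ring such as cyclohexyl, at this same place would be needed to tell the two apart. Also open, on these data alone, is whether a group that brings hydrogen-bond donors or acceptors to this place, such as an amine or a carboxylic acid, moves the number in the same direction, by a similar amount, or not at all.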